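The source may report more compounds than this note shows. Statements on the series, on what has been measured and on what is new or still open speak of the compounds shown alone.

Measured compounds
- compound 1 `CCC(CC)CN1CCC(C(=O)Nc2cc(Cl)c(N)cc2OC)CC1` — > 10 mg/kg
- compound 2 `COc1cc(N)c(Cl)cc1NC(=O)C1CCN(Cc2cccc(Cl)c2)CC1` — > 4 mg/kg

In a functional assay on the whole organism for antagonist activity, with Mus musculus as the target (a higher number here means that more compound is needed for the effect, a lower number that less compound is needed), compound 1 gives > 10 mg/kg, which is a limit of the assay and not a number. In this assay compound 2 gives > 4 mg/kg, likewise a limit. The step that the two limits leave unreadable from compound 1 to compound 2 cannot be sized, since both results sit at limits, as the limit of > 10 mg/kg in this assay, at which 1 of the 2 values shown sits, and the limit of > 4 mg/kg in this assay, at which 1 of the 2 values shown sits, show. Compound 2 thus stands only at a limit, with no measured number anywhere in the series to place it against.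

Compound 3 `CCOc1ccc(CN2CCC(C(=O)Nc3cc(Cl)c(N)cc3OC)CC2)cc1` differs from compound 2 by 4-ethoxyphenyl in place of 3-chlorophenyl on a saturated chain carbon bound to an amine nitrogen in a ring. Among the measured compounds shown here, the one measured step at this position, a step that the two limits leave unreadable from compound 1 to compound 2, gives no size, so no direction beyond the scatter can be read for this assay from the data in hand.

Compound 3 is expected to give 10 mg/kg in this assay, within 2 mg/kg to 40 mg/kg, and most probably to be reported again as a limit. The step that the limit leaves unreadable from compound 2 to compound 3 that this estimate means is expected to stay within the scatter.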

Compound 3, dose for half-maximal effect: 6.3 mg/kg
For compound 3 the middle estimate is 1.6-fold (0.20 log units) above the measured one; the range from low to high includes it.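

Among the compounds shown here, with compound 3, this position, on a saturated chain carbon bound to an amine nitrogen in a ring, yields a measured number in this assay for the first time, not only a limit. Replacing pentan-3-yl with 4-ethoxyphenyl gives an at least 1.5-fold lower number from compound 1 to compound 3 (0.20 log units; that floor lies within the scatter), so the data show a lower number only as a floor, and that floor does not establish a change beyond the scatter. The steps that involve compound 2 cannot be read, so 4-ethoxyphenyl and 3-chlorophenyl cannot be ranked at this position.

On these data alone, it remains open how far the true step from pentan-3-yl to 4-ethoxyphenyl exceeds that floor. Also open, as far as these compounds go, is how a plain phenyl, 4-methoxyphenyl or 4-propoxyphenyl at this position would read in this assay, and thus whether the ethoxy group itself matters.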